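Moving the carboxylate around the pyridine ring of compound 3

This account rests on a few compounds, and the source may have more. Where it says the series, first, only, none or still open, it means among the compounds named here.

Measured compounds in an assay on isolated protein for activation of cGMP-dependent protein kinase 1 (Homo sapiens), read by ADP-Glo, with stated times of 120 min and 40 min; a higher number here means that more compound is needed for the effect, a lower number that less compound is needed:
compound 1, `O=C(O)c1cncc(CN2CCC[C@H](O[C@H](CO)c3cc(Cl)cc(Cl)c3)[C@@H]2c2ccccc2)c1`: 34000 nM
compound 2, `O=C(O)c1ccc(CN2CCC[C@H](O[C@H](CO)c3cc(Cl)cc(Cl)c3)[C@@H]2c2ccccc2)cc1`: 11000 nM
compound 3, `O=C(O)c1cncc(CN2CCC[C@H](OCc3cc(Cl)cc(Cl)c3)[C@@H]2c2ccccc2)c1`: 117000 nM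

Compound 3 stands at the highest number of the three. Compound 1 lies nearest to it, with a 3.4-fold higher number from compound 1 to compound 3 (0.54 log units; beyond the scatter) separating them, and compound 2 lies furthest away. The other step that has been measured is a 3.1-fold lower number from compound 1 to compound 2 (0.49 log units; beyond the scatter), a modest change of the carboxyaryl group on the saturated chain carbon bound to the amine nitrogen in the ring.

Compound 4, `O=C(O)c1ccc(CN2CCC[C@H](OCc3cc(Cl)cc(Cl)c3)[C@@H]2c2ccccc2)cn1`, keeps the shared core and the hydrogen of compound 3 and differs from it only in the carboxypyridinyl group: 6-carboxypyridin-3-yl in place of 5-carboxypyridin-3-yl on a saturated chain carbon bound to an amine nitrogen in a ring. Among the measured compounds shown here, no measured step moves the carboxylate within a pyridine ring; the closest comparison is the exchange of the carboxypyridinyl for a carboxyphenyl between compound 1 and compound 2, which was modest in size. A change of this sort is therefore expected to give at most a modest step in this assay, with the direction uncertain, and a step of a 1.5-fold lower number from compound 3 to compound 4 (0.17 log units; within the scatter) is the estimate. Compound 4 is thus expected to give about 80000 nM in this assay, within a range from 25000 nM to 250000 nM.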

Compound 4, half-maximal effective concentration: > 200000 nM
Compound 4: only a limit was reported (the forecaster's own chance of this, stated with the estimate: 15%); middle value at least 2.5-fold (0.39 log units) from the limit.
By their numbers in this assay, from the lowest: compound 2; then compound 1; then compound 3. At a limit, above all of these: compound 4.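

Exchanging 5-carboxypyridin-3-yl for 6-carboxypyridin-3-yl on the saturated chain carbon bound to the ring amine nitrogen leaves the atoms of the group unchanged, and in this assay it gives an at least 1.7-fold higher number from compound 3 to compound 4 (0.23 log units; that floor lies within the scatter). Among the compounds shown here, the only earlier change at this place was a 3.1-fold lower number from compound 1 to compound 2 (0.49 log units; beyond the scatter), which replaced a pyridine ring with a benzene ring, whereas here a rearrangement of the same atoms is enough to leave the number no lower than that of compound 3. The true size of the new step cannot be read, since the floor printed with it is all that is known and the reading for compound 4 is a limit of the assay, not a number: the limit of > 200000 nM in this assay, at which 1 of the 4 values shown sits.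

It remains open whether 6-carboxypyridin-3-yl would give a measurable number with the hydroxymethyl group of compound 1 on the chain carbon bound to the aromatic carbon, the group present in the two lowest numbers shown. Also open, on these data alone, is how a carboxamide, a tetrazole or a longer chain carrying the carboxylic acid would fare at this place.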